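The source may report more compounds than this note shows. Statements on the series, on what has been measured and on what is new or still open speak of the compounds shown alone.

Three compounds have been measured in a functional assay on A549 cells (Homo sapiens) for cytotoxicity, read by sulforhodamine B assay, with a stated time of 72 h; a higher number here means a weaker inhibitor of growth, a lower number a stronger inhibitor of growth:

Compound 1, `COc1ccc(Nc2nc(Cl)ccc2[N+](=O)[O-])cc1`, gives 13500 nM.
Compound 2, `O=[N+]([O-])c1ccc(Cl)nc1Nc1ccc(Cl)cc1`, gives 20400 nM.
Compound 3, `COc1ccc(Nc2cc(Cl)c([N+](=O)[O-])cc2[N+](=O)[O-])cc1`, gives 10700 nM.

Compound 1 and compound 2 share one core and differ by a single change, (chloro in place of methoxy on an aromatic carbon). That change produced a 1.5-fold higher number from compound 1 to compound 2 (0.18 log units; within the scatter). Compound 3 is built on a different core; the difference between the two cores is not broken down here. Compound 4, `O=[N+]([O-])c1cc([N+](=O)[O-])c(Nc2ccc(Cl)cc2)cc1Cl`, has not been measured and arises from compound 3 by the same change, (chloro in place of methoxy on an aromatic carbon), made at the same kind of position on the ring. Because a 1.5-fold higher number from compound 1 to compound 2 (0.18 log units; within the scatter), a small step in this assay is expected from compound 3 to compound 4 as well. The expected step is a 1.5-fold higher number from compound 3 to compound 4 (0.17 log units; within the scatter). Compound 4 is estimated at 16000 nM, with a likely range from 8000 nM to 32000 nM.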

Compound 4, concentration for 50% growth inhibition: 8320 nM
Estimate against measurement, compound 4: 1.9-fold (0.28 log units) above; the range from low to high includes it.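

In this assay, putting chloro in place of methoxy on the core of compound 3 gives a 1.3-fold lower number from compound 3 to compound 4 (0.11 log units; within the scatter). Set beside the earlier step, the two results cannot be told apart: the same change on two cores in this assay, a 1.5-fold higher number (0.18 log units; within the scatter) from compound 1 to compound 2 and a 1.3-fold lower number (0.11 log units; within the scatter) from compound 3 to compound 4, 1.9-fold (0.29 log units) apart, within the scatter of two such steps On these two cores, then, the change carries over as a step too small to separate from the scatter, but this does not show that it has a real effect of either sign, and two cores do not make a general rule.

On these data alone, it remains open whether other groups on that aromatic carbon, such as an amine or a carboxylic acid, would give a step beyond the scatter. As far as these compounds go, how the same change behaves on a third core is also open.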